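The source may hold more compounds than are shown below. What is called first, only, known or untested is meant among the compounds shown, and "the series" means these compounds.

Working notes on the series. The shared core is carried by compound 1 `O=C(CSc1nc(Nc2ccccc2)c2ccccc2n1)Nc1ccc(Cl)cc1`, compound 2 `CCc1ccc(NC(=O)CSc2nc(Nc3ccccc3)c3ccccc3n2)cc1`, compound 3 `C=CC(=O)Nc1cccc(NC(=O)CSc2nc(Nc3cccc(Br)c3)c3ccccc3n2)c1` and the still unmeasured compound 4 `C=CC(=O)Nc1cccc(NC(=O)CSc2nc(Nc3ccc(F)c(Cl)c3)c3ccccc3n2)c1`. In a functional assay on MGC-803 cells (Homo sapiens) for inhibition, read by MTT assay, with a stated time of 72 h (a higher number here means a weaker inhibitor, a lower number a stronger inhibitor), compound 1 gives 40400 nM. Compound 2 reaches only a limit of the assay, > 50000 nM, as the limit of > 50000 nM in this assay, at which 1 of the 3 values shown sits, records. Within the data shown here, the one measured single-place change is an at least 1.2-fold higher number from compound 1 to compound 2 (0.09 log units; that floor lies within the scatter), on a different ring from the one altered below. Compound 3 gives 11900 nM, the lowest of the two numbers shown, with compound 1 nearest. Compound 4 differs from compound 3 by 3-chloro-4-fluorophenyl in place of 3-bromophenyl on a nitrogen on an aromatic ring. Among the measured compounds shown here, no measured step bears on this nitrogen, so no shift beyond the scatter is anticipated. Compound 4 is therefore expected close to compound 3, with a step of a 1.0-fold higher number from compound 3 to compound 4 (0.00 log units; within the scatter), at an estimate of 12000 nM (range 4000 nM to 40000 nM).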

Compound 4, half-maximal inhibitory concentration: 7850 nM
For compound 4 the middle estimate is 1.5-fold (0.18 log units) above the measured one, within the range that was stated.
By their numbers in this assay, from the lowest: compounds 4 and 3 (each within the scatter of the next); then compound 1. At a limit, above all of these: compound 2.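

In this assay, among these compounds, 3-chloro-4-fluorophenyl in place of 3-bromophenyl on this nitrogen gives a 1.5-fold lower number from compound 3 to compound 4 (0.18 log units; within the scatter), the only measured step at this position. The two halogenated phenyl groups are therefore not told apart here. No measurement shown bears on the cause of this result.

Left open is how this position responds to a methoxy group or a carboxylic acid on the phenyl ring. Among the compounds shown here, no single-place step links compound 3 or compound 4 to compound 1 or compound 2, so the effect of the other differences also remains open.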